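Removing the Methyl from the Triazole Aryl Group

A few compounds are considered here, and "the series" means these few. Any claim that something is new, unique, unknown or untested is made for them only; others in the source may bear on it.

Measured so far:
compound 2 `C=C1C(=O)[C@]23C[C@@]1(O)CC[C@H]2c1ccc(O)c(C)c1[C@@H]3Cn1cc(-c2ccc(C)cc2)nn1`, 330 nM
compound 3 `C=C1C(=O)[C@]23C[C@@]1(O)CC[C@H]2c1ccc(OS(=O)(=O)c2ccc(C)cc2)c(C)c1[C@@H]3Cn1cc(-c2ccc(C)cc2)nn1`, 1460 nM
compound 1 `C=C1C[C@]23C[C@@]1(O)CC[C@H]2c1ccc(O)c(C)c1[C@@H]3Cn1cc(-c2ccc(C(F)(F)F)cc2)nn1`, > 20000 nM

Of the compounds shown here, three sharing one core have been tested in a functional assay on SW480 cells (Homo sapiens) for cytotoxicity, read by MTT assay, with a stated time of 4 days; on this read-out lower numbers stand for stronger inhibition and higher numbers for weaker inhibition. Compound 2 gives 330 nM, the lowest of the two numbers recorded. Compound 3, which carries (4-methylphenyl)sulfonyl in place of hydrogen on an oxygen on an aromatic ring, gives 1460 nM; the step of a 4.4-fold higher number from compound 2 to compound 3 (0.65 log units; beyond the scatter) is modest. Compound 1 lacks the carbonyl of the core, and its result in this assay is only a limit, > 20000 nM, as stated by the limit of > 20000 nM in this assay, at which 1 of the 3 values shown sits.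

Compound 4 `C=C1C(=O)[C@]23C[C@@]1(O)CC[C@H]2c1ccc(O)c(C)c1[C@@H]3Cn1cc(-c2ccccc2)nn1` has not yet been measured. It differs from compound 2 by hydrogen in place of methyl on an aromatic carbon. Going by the values given here, no measured step touches this part of the molecule; the only quantified step, between compound 2 and compound 3, concerns the oxygen on the aromatic ring of the core and gives no guidance here. Compound 4 is therefore expected to remain close to compound 2, with a step of a 1.2-fold higher number from compound 2 to compound 4 (0.08 log units; within the scatter) that is not expected to exceed the scatter. The estimate for compound 4 is 400 nM, with a range from 150 nM to 1200 nM.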

Compound 4, half-maximal inhibitory concentration: 260 nM
The estimate for compound 4 lay 1.5-fold (0.19 log units) above the measured number; measured number inside the range.
By their numbers in this assay, from the lowest: compounds 4 and 2 (each within the scatter of the next); then compound 3. At a limit, above all of these: compound 1.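

In this assay, replacing 4-methylphenyl with phenyl gives a 1.3-fold lower number from compound 2 to compound 4 (0.10 log units; within the scatter). Going by these compounds alone, this is the first reading at this position, on an aromatic carbon para to a large group, and it shows that the methyl can give way to hydrogen with no difference beyond the scatter, so the methyl is not needed to keep a value of this order on the shared core. Nothing measured here offers an explanation for this result.

Compound 1 carries trifluoromethyl on the same ring but also lacks the core carbonyl, so it cannot show what that group does at this position on its own. On these data alone, how an amine, a carboxylic acid or a longer chain at this carbon would read remains open.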